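Fluoro to Chloro on a Fused Ring: Compound 3

A few compounds are considered here, and "the series" means these few. Any claim that something is new, unique, unknown or untested is made for them only; others in the source may bear on it.

Compound 1 `O=C(Nc1nc2ccc(Cl)cc2s1)c1cn(-c2ccccc2)nc1-c1ccc(Cl)cc1`: 4360 nM
Compound 2 `COc1ccc(-c2nn(-c3ccccc3)cc2C(=O)Nc2nc3ccc(F)cc3s2)cc1`: 7560 nM

Both numbers come from a functional assay on A549 cells (Homo sapiens) for cytotoxicity, read by MTT assay, with a stated time of 72 h; on this read-out lower numbers stand for stronger inhibition and higher numbers for weaker inhibition. Compound 2 carries the higher of the two, yet the gap to compound 1 lies within the usual scatter, so the two are not truly separated.

Compound 3 `COc1ccc(-c2nn(-c3ccccc3)cc2C(=O)Nc2nc3ccc(Cl)cc3s2)cc1` differs from compound 2 by chloro in place of fluoro on an aromatic carbon. Going by the values given here, no measured pair shows how large such a swap is in this assay, so only a small step is expected, if any, probably not beyond the scatter. For compound 3 the estimate is 5500 nM, with a range from 2500 nM to 12000 nM. This corresponds to an expected step of a 1.4-fold lower number from compound 2 to compound 3 (0.14 log units; within the scatter).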

Compound 3, half-maximal inhibitory concentration: 4710 nM
The estimate for compound 3 lay 1.2-fold (0.07 log units) above the measured number, within the range that was stated.
By their numbers in this assay, from the lowest: compounds 1, 3 and 2 (each within the scatter of the next).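

In this assay, the change from 6-fluoro-1,3-benzothiazol-2-yl to 6-chloro-1,3-benzothiazol-2-yl gives a 1.6-fold lower number from compound 2 to compound 3 (0.21 log units; within the scatter), so these two halogens are not told apart here. Methoxy in place of chloro on an aromatic carbon gives a 1.1-fold higher number from compound 1 to compound 3 (0.03 log units; within the scatter), and this pair is not separated either. No supporting measurement is available to explain these results. Going by these compounds, it stays open whether an amine or a carboxylic acid on this aromatic carbon would move the number beyond the usual scatter.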